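Sulfonamide Substituent Swap on a Shared Core in Vero Cells

The source may hold more compounds than are shown below. What is called first, only, known or untested is meant among the compounds shown, and "the series" means these compounds.

Compound 1 `Cc1ccc(N(C)S(=O)(=O)C2CC3OC2C(c2ccc(NC(=O)CCCCCCC(=O)O)cc2)=C3c2ccc(O)cc2)cc1` bears a methyl(4-methylphenyl)amino group on a sulfonyl sulfur of the shared core. In an ADME assay on Vero cells (Chlorocebus sabaeus) for antiproliferative activity, read by MTT assay, with a stated time of 72 h (a higher number here means a weaker inhibitor, a lower number a stronger inhibitor), compound 1 gives only a limit, > 100000 nM, and not a number. Compound 2 `CN(c1cccc2ccccc12)S(=O)(=O)C1CC2OC1C(c1ccc(NC(=O)CCCCCCC(=O)O)cc1)=C2c1ccc(O)cc1` has naphthalen-1-yl in place of 4-methylphenyl on a sulfonamide nitrogen. In this assay compound 2 again reaches only a limit, > 100000 nM. The step that the two limits leave unreadable from compound 1 to compound 2 is thus unreadable, since both values sit at the limit of > 100000 nM in this assay, at which 2 of the 2 values shown sit. Compound 3 `CCN(c1ccc(OC)cc1)S(=O)(=O)C1CC2OC1C(c1ccc(NC(=O)CCCCCCC(=O)O)cc1)=C2c1ccc(O)cc1` is not yet measured and differs from compound 1 by ethyl(4-methoxyphenyl)amino in place of methyl(4-methylphenyl)amino on a sulfonyl sulfur. Within the data shown here, the single measured step offers no readable size and no direction, so the only expectation that can be drawn is that compound 3 stays at the limit in this assay. Compound 3 is therefore expected at 150000 nM, within 50000 nM to 500000 nM, which means an expected step that the limit leaves unreadable from compound 1 to compound 3.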

Compound 3, half-maximal inhibitory concentration: > 100000 nM
Compound 3: only a limit was reported; the forecaster's own chance of this, stated with the estimate: 85%; the middle value does not contradict the limit.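

In this assay compound 3 gives > 100000 nM, which is a limit and not a number. Among these compounds, no step from compound 1 or compound 2 to compound 3 can be read: the limit of > 100000 nM in this assay, at which 3 of the 3 values shown sit. The compounds shown leave open whether any substituent on the sulfonyl sulfur of the shared core would give a measurable value in this assay.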